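Swapping One Halogen for Another

The source may hold more compounds than are shown below. What is called first, only, known or untested is meant among the compounds shown, and "the series" means these compounds.

- compound 1 `O=c1[nH]c(N/N=C/c2ccccc2)nc2nc(-c3cccs3)cc(-c3ccccc3)c12`: 32100 nM
- compound 2 `O=c1[nH]c(N/N=C/c2ccc(F)cc2)nc2nc(-c3cccs3)cc(-c3ccccc3)c12`: 3360 nM

In a functional assay on A549 cells (Homo sapiens) for cytotoxicity, read by sulforhodamine B assay, with a stated time of 48 h (a higher number here means a weaker inhibitor, a lower number a stronger inhibitor), compound 2 has the lower of the two numbers, 3360 nM. Compound 3 `O=c1[nH]c(N/N=C/c2ccc(Cl)cc2)nc2nc(-c3cccs3)cc(-c3ccccc3)c12` differs from it at one place: chloro in place of fluoro on an aromatic carbon. Among the compounds with values here, one measured step bears on this, a 9.6-fold lower number from compound 1 to compound 2 (0.98 log units; beyond the scatter), where fluoro replaced hydrogen. That step was modest, and it did not exchange one halogen for another, so in this assay no step beyond the scatter is expected, in either direction. The estimated step is a 1.1-fold higher number from compound 2 to compound 3 (0.05 log units; within the scatter). For compound 3 the expected value is 3800 nM, with an estimated range of 1500 nM to 10000 nM.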

Compound 3, half-maximal inhibitory concentration: 40800 nM
For compound 3 the middle estimate is 11-fold (1.03 log units) below the measured one; the whole stated range lies below it.
By their numbers in this assay, from the lowest: compound 2; then compounds 1 and 3 (each within the scatter of the next).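

In this assay the identity of the halogen at this ring position matters, not just its presence: chloro in place of fluoro gives a 12-fold higher number from compound 2 to compound 3 (1.08 log units; beyond the scatter) while chloro in place of hydrogen gives a 1.3-fold higher number from compound 1 to compound 3 (0.10 log units; within the scatter) and so no change beyond the scatter. The gain seen with fluoro therefore does not carry over to chloro, and among these three compounds only compound 2 stands apart. Nothing available explains this difference between the two halogens. On these data alone, whether bromo, methoxy or an amine at this position would behave like fluoro or like chloro remains open.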